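A fourth group on the same carbonyl carbon

A few compounds are considered here, and "the series" means these few. Any claim that something is new, unique, unknown or untested is made for them only; others in the source may bear on it.

Measured in an ADME assay on microsomes from liver (Homo sapiens) for metabolic stability, with a stated time of 60 min, tested at 10 uM (on this read-out higher numbers stand for a more stable compound and lower numbers for a less stable compound), the three compounds read as follows:
Compound 1 `CCCS(=O)(=O)N1CCN(C2(CNC(=O)c3ccccc3OC(F)(F)F)CCCCC2)CC1` gives 2%
Compound 2 `CCCS(=O)(=O)N1CCN(C2(CNC(=O)c3ccc(OC(F)(F)F)cc3)CCCCC2)CC1` gives 11%
Compound 3 `CCCS(=O)(=O)N1CCN(C2(CNC(=O)c3cccc(C(F)(F)F)c3Cl)CCCCC2)CC1` gives 1%

Compound 3 stands at 1% and lies within the scatter of the other two, with a number 1 percentage points lower from compound 1 to compound 3 (within the scatter) and a number 10 percentage points lower from compound 2 to compound 3 (within the scatter) on the record. Compound 4 `CCCS(=O)(=O)N1CCN(C2(CNC(=O)c3ccc(F)cc3C)CCCCC2)CC1` carries a single change 4-fluoro-2-methylphenyl in place of 2-chloro-3-(trifluoromethyl)phenyl on a carbonyl carbon in which 4-fluoro-2-methylphenyl stands in place of 2-chloro-3-(trifluoromethyl)phenyl on a carbonyl carbon. The measured steps that bear on this all exchange the group at that same place. Together with the two above, a number 9 percentage points higher from compound 1 to compound 2 (within the scatter) completes the set, and none of the three leaves the scatter. The entering group itself has not been measured, so no step beyond the scatter is expected in this assay for this change. The estimated step is a number 7 percentage points higher from compound 3 to compound 4 (within the scatter) as the expected outcome. Compound 4 is estimated at 8% with an expected range from 1% to 22% in repeated measurements.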

Compound 4, percent of the compound remaining: 2%
For compound 4 the middle estimate is 6 percentage points above the measured one; low and high end bracket the measured number.
By their numbers in this assay, from the lowest: compounds 3, 1, 4 and 2 (each within the scatter of the next).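

In the assay (this assay), the new group on the carbonyl carbon stays within the scatter of all three earlier groups, with a number 1 percentage points higher from compound 3 to compound 4 (within the scatter) and a number 9 percentage points lower from compound 2 to compound 4 (within the scatter) and no change at the digits printed from compound 1 to compound 4 (within the scatter) on record. The 4-fluoro-2-methylphenyl group has fewer heavy atoms than 2-chloro-3-(trifluoromethyl)phenyl, and a single fluorine against three, yet this exchange of aryl groups produces no step beyond the scatter. Nothing available here accounts for these readings.

The compounds shown leave open whether any group at this place can move the reading beyond the scatter, for instance a phenyl group carrying an amine or a carboxylic acid. They also leave open whether a change elsewhere on the shared core would do so.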